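The source may report more compounds than this note shows. Statements on the series, on what has been measured and on what is new or still open speak of the compounds shown alone.

Compound 1 `CN(C)/N=N/c1ccc(C(N)=O)cc1` is the starting point; in a functional assay on L1210 cells (Mus musculus) for antiproliferative activity (a lower number here means a less potent compound, a higher number a more potent compound, by a factor of ten per unit of this negative logarithm), compound 1 gives 3.51. Compound 2 `COC(=O)c1ccc(/N=N/N(C)C)cc1` differs from it in one place, (methoxy in place of amino on a carbonyl carbon), and in this assay compound 2 gives 3.2. That change made the step of a number 0.31 log units lower from compound 1 to compound 2 (beyond the scatter). Compound 3 `CN(C)/N=N/c1n[nH]cc1C(N)=O` is built on another core; how the core of compound 3 differs from the core of compound 1 is not broken down here. In this assay compound 3 gives 3.49, a number that sits within the scatter of compound 1. Compound 4 `COC(=O)c1c[nH]nc1/N=N/N(C)C` has not yet been measured. It differs from compound 3 in one place, (methoxy in place of amino on a carbonyl carbon), and the place is described in the same words as for compound 2 against compound 1, so this is the same change, seen twice among these compounds. For the measured compounds named here, because the one earlier example of this change made the step of a number 0.31 log units lower from compound 1 to compound 2 (beyond the scatter), a step of similar size is expected from compound 3 to compound 4, a number 0.31 log units lower from compound 3 to compound 4 (beyond the scatter), an expectation that rests on a single pair. Compound 4 is therefore estimated at 3.18, with a likely range from 2.8 to 3.55.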

Compound 4, logarithm of the reciprocal of the active concentration, log(1/C): 3.49
The estimate for compound 4 lay 0.31 log units below the measured number; the range from low to high includes it.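

In this assay, methoxy in place of amino on a carbonyl carbon gives a flat result on the core of compound 3 (no change at the digits printed from compound 3 to compound 4 (within the scatter)), whereas the same change on the core of compound 1 gave a modest drop. Set side by side, these two steps cannot be told apart: the same change on two cores in this assay, a number 0.31 log units lower (beyond the scatter) from compound 1 to compound 2 and no change at the digits printed (within the scatter) from compound 3 to compound 4, 0.31 log units apart, within the scatter of two such steps. For the compounds shown here, this shows that one pair on one core was a weak guide to the other core, but it does not show that the core alters the effect of this change, nor that the effect carries over unchanged, since each core offers only a single small step.

Still open, going by these compounds, is how a carboxylic acid or an ethoxy group on the same carbonyl carbon would read on these two cores. A group of that kind might also show whether the cores really part ways, which a single swap of amino for methoxy cannot settle.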